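The source may hold more compounds than are shown below. What is called first, only, known or untested is meant among the compounds shown, and "the series" means these compounds.

Compound 1 `COc1cccc(N2CCN(C(=O)CN3C(=O)CC(C)(c4ccccc4)C3=O)CC2)c1` was tested in a functional assay on the whole organism (strain CD-1) with Mus musculus as the target, with a stated time of 0.5 h; a higher number here means that more compound is needed for the effect, a lower number that less compound is needed. In this assay compound 1 gives 100 mg/kg. Compound 2 `CC1(c2ccccc2)CC(=O)N(CC(=O)N2CCC(Cc3ccccc3)CC2)C1=O` shares the core of compound 1. In this assay compound 2 gives 100 mg/kg, so compound 1 stands level with compound 2 at the digits reported, and the two values lie within the usual scatter of each other. Compound 3 `CC1(c2ccccc2)CC(=O)N(CC(=O)N2CCN(c3ccc(F)cc3)CC2)C1=O` has not yet been tested. It differs from compound 1 in one place: 4-fluorophenyl in place of 3-methoxyphenyl on an amine nitrogen in a ring. For the measured compounds named here, no measured pair of compounds shows what this change does to the dose, so no step beyond the scatter is expected in either direction, and the step from compound 1 to compound 3 is estimated as no change at the digits printed from compound 1 to compound 3 (within the scatter). In this assay compound 3 is therefore expected to give about 100 mg/kg, with a range from 30 mg/kg to 300 mg/kg.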

Compound 3, minimum effective dose: "not active" (no number reported)
No number was reported for compound 3, so the estimate cannot be set against anything.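

Compound 3 is reported in this assay only as not active, without a number, so no step from compound 1 to compound 3 can be read, and nothing measured here offers an explanation.

The compounds shown leave open how 4-fluorophenyl in place of 3-methoxyphenyl changes the dose needed.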